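Swapping the aryl amide of compound 3 for a piperidine amide

The source may hold more compounds than are shown below. What is called first, only, known or untested is meant among the compounds shown, and "the series" means these compounds.

Compound 1 `O=C(CCC(=O)OCCCCCCSc1ccc([N+](=O)[O-])c2nonc12)Nc1cccc(Cl)c1`: 28800 nM
Compound 2 `O=C(CCC(=O)OCCCCCCSc1ccc([N+](=O)[O-])c2nonc12)Nc1ccc(Br)cc1`: 5090 nM
Compound 3 `COc1ccc(NC(=O)CCC(=O)OCCCCCCSc2ccc([N+](=O)[O-])c3nonc23)cc1`: 420 nM

These three compounds were tested in an assay on isolated protein for inhibition of glutathione S-transferase P (Homo sapiens), with a stated time of 10 min; on this read-out higher numbers stand for weaker inhibition and lower numbers for stronger inhibition. Compound 3 stands lowest of the three numbers; the nearest is compound 2, and the step of a 12-fold lower number from compound 2 to compound 3 (1.08 log units; beyond the scatter) came with methoxy in place of bromo on an aromatic carbon. The furthest is compound 1, and a 69-fold lower number from compound 1 to compound 3 (1.84 log units; beyond the scatter) came with 4-methoxyphenyl in place of 3-chlorophenyl on an amide-type nitrogen. The remaining step, a 5.7-fold lower number from compound 1 to compound 2 (0.75 log units; beyond the scatter), was modest.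

Compound 4 `O=C(CCC(=O)N1CCCCC1)OCCCCCCSc1ccc([N+](=O)[O-])c2nonc12` differs from compound 3 in one place: piperidin-1-yl in place of (4-methoxyphenyl)amino on a carbonyl carbon. Within the data shown here, none of the measured steps bears directly on this change; all three vary only the substituent on the aryl ring while keeping the aryl amide itself. What they do show is that this region is sensitive, since the whole measured range is spanned by changes there. Removing the aryl ring and the amide hydrogen altogether is a larger change than any measured one, so a sizeable rise in the number is expected, with wide uncertainty: compound 4 is estimated at 8000 nM (range 1500 nM to 40000 nM), which would mean an expected step of a 19-fold higher number from compound 3 to compound 4 (1.28 log units; beyond the scatter).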

Compound 4, half-maximal inhibitory concentration: 500 nM
Compound 4: middle estimate off by 16-fold (1.20 log units), on the high side; measured number below the stated range.
By their numbers in this assay, from the lowest: compounds 3 and 4 (each within the scatter of the next); then compound 2; then compound 1.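

In this assay, the replacement of the aryl amide by the piperidine amide gives a 1.2-fold higher number from compound 3 to compound 4 (0.08 log units; within the scatter), so among these compounds neither the aromatic ring nor the amide hydrogen is needed for a number at this level. The same group also gives a 10-fold lower number from compound 2 to compound 4 (1.01 log units; beyond the scatter) and a 58-fold lower number from compound 1 to compound 4 (1.76 log units; beyond the scatter), which shows that the sensitivity seen earlier at this position does not amount to a requirement for an aryl amide, and that a non-aromatic ring with no hydrogen-bond donor can stand on this carbonyl carbon alongside the best of the aryl amides. Nothing available here explains why (4-methoxyphenyl)amino and piperidin-1-yl give numbers within the scatter of each other while the bromo and chloro aryl amides stand well apart from both.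

The compounds shown leave open whether a morpholine amide, a dimethylamide or a free carboxylic acid on this carbonyl carbon would give a number at this level. They also leave open whether a methoxy group or a halogen on the piperidine ring would move the number as far as such groups did on the aryl ring.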